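Two Weak Sulfonamides and a Dimethoxyphenyl Analogue

The compounds below may be only part of what the source reports. "The series", "measured", "known", "first", "only" and "open" are said of these compounds alone.

Measured so far:
- Compound 1, `Cc1ccc(S(=O)(=O)N(Cc2nc3ccccc3[nH]2)c2ccc(F)cc2)cc1`, in a functional assay on PC-3 cells (Homo sapiens) for inhibition, read by MTT assay, with a stated time of 48 h; on this read-out higher numbers stand for weaker inhibition and lower numbers for stronger inhibition: 45000 nM.
- Compound 2, `Cc1ccc(S(=O)(=O)N(Cc2nc3ccccc3[nH]2)c2ccccc2)cc1`, a limit of the assay: > 50000 nM.

Both values are weak. Among the compounds with values here, compound 1 is the only one that gives a number. On these data alone, compound 2 stands at the limit of > 50000 nM in this assay, at which 1 of the 2 values shown sits, so where it lies beyond that is unknown. Within the data shown here, the single measured step, an at least 1.1-fold higher number from compound 1 to compound 2 (0.04 log units; that floor lies within the scatter), is within the scatter, and it says nothing about the change now considered.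

Compound 3, `COc1ccc(N(Cc2nc3ccccc3[nH]2)S(=O)(=O)c2ccc(C)cc2)cc1OC`, differs from compound 2 by 3,4-dimethoxyphenyl in place of phenyl on a sulfonamide nitrogen. Among the measured compounds shown here, no measured pair involves a dimethoxyphenyl, so there is no step to build on. The estimated step is an at least 1.2-fold lower number from compound 2 to compound 3 (0.09 log units; that floor lies within the scatter), which is expected to stay near the limit where compound 2 sits. For compound 3 the expected value is 40000 nM, with a range from 12000 nM to 100000 nM.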

Compound 3, half-maximal inhibitory concentration: > 50000 nM
Compound 3 gave a limit, no number; the forecaster's own chance of this, stated with the estimate: 45%; middle value at least 1.2-fold (0.09 log units) from the limit.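

Putting 3,4-dimethoxyphenyl on the sulfonamide nitrogen brings no readable gain in this assay: compound 3, like compound 2, reaches only a limit of the assay and gives no number. Set against 4-fluorophenyl, the change gives an at least 1.1-fold higher number from compound 1 to compound 3 (0.04 log units; that floor lies within the scatter), so this floor alone shows no difference beyond the scatter. The step between the two limits cannot be read, and the values now gather at one ceiling: the limit of > 50000 nM in this assay, at which 2 of the 3 values shown sit.

On these data alone, how far compound 2 and compound 3 lie beyond that limit stays unknown, and so does whether any group on this nitrogen can give a clearly stronger value. A phenyl ring carrying an amine or a carboxylic acid, or a longer saturated chain in place of the ring, would probe this position with groups quite unlike those shown so far.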